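The source may report more compounds than this note shows. Statements on the series, on what has been measured and on what is new or still open speak of the compounds shown alone.

Measured compounds:
Compound 1 `COc1cc2ncnc(Nc3ccc(OC(F)(F)F)cc3)c2cc1OCCCCC(=O)Nc1ccc(S(N)(=O)=O)cc1` gives 22500 nM in a functional assay on A-431 cells (Homo sapiens) for antiproliferative activity, read by MTT assay, with a stated time of 72 h; a higher number here means a weaker inhibitor, a lower number a stronger inhibitor.
Compound 2 `NS(=O)(=O)c1ccc(NC(=S)Nc2ccc3ncnc(Nc4ccc(F)c(Br)c4)c3c2)cc1` gives 18200 nM in this assay.

Within the data shown here, only these two numbers frame the series so far. Compound 2, a thiourea-linked quinazoline, and compound 1, which carries an amide-linked chain instead, sit so close together that the gap between them lies within the usual scatter of this assay, so neither can be called the stronger inhibitor on this evidence. Both are weak.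

Compound 3 `NS(=O)(=O)c1ccc(NC(=S)Nc2ccc3ncnc(Nc4cccc(Cl)c4)c3c2)cc1` is the next member. It differs from compound 2 in one place: 3-chlorophenyl in place of 3-bromo-4-fluorophenyl on a nitrogen on an aromatic ring. Among the measured compounds shown here, no measured pair shows what this exchange does in this assay, so the expectation rests on the closeness of compound 1 and compound 2 alone. Given that compound 2 gives 18200 nM and the structural change is confined to the halogen pattern on one aromatic ring, the step of a 1.2-fold higher number from compound 2 to compound 3 (0.08 log units; within the scatter) is expected to stay within the scatter, with no clear direction. Compound 3 is accordingly estimated at 22000 nM, within a range from 7000 nM to 70000 nM in this assay.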

Compound 3, half-maximal inhibitory concentration: 15000 nM
Beside the measured number, compound 3's estimate is 1.5-fold (0.17 log units) above it, within the range that was stated.
By their numbers in this assay, from the lowest: compounds 3, 2 and 1 (each within the scatter of the next).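

Compound 2 and compound 3 form the only pair shown that differs at this position alone, and in this assay the exchange of 3-bromo-4-fluorophenyl for 3-chlorophenyl on a nitrogen on an aromatic ring comes to a 1.2-fold lower number from compound 2 to compound 3 (0.08 log units; within the scatter), so the two compounds cannot be told apart. The pair therefore adds a direct reading that the comparison of compound 1 with compound 2 could not give, since those two differ in more than one place: with the thiourea-linked core held fixed, compound 2 gives 18200 nM and compound 3 gives 15000 nM, and this particular halogen exchange leaves both compounds weak. No measurement on hand offers any explanation for this result.

The compounds shown leave open whether a group of another kind at this position, such as an unsubstituted phenyl, a 3-methoxyphenyl or a 3-aminophenyl, would move the number beyond the scatter. They also leave open whether any change at this position matters more than a change of the thiourea link itself, for example to a urea.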